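Ethylsulfanyl in place of cyclobutyl on the shared core

The source may report more compounds than this note shows. Statements on the series, on what has been measured and on what is new or still open speak of the compounds shown alone.

Compound 1 `Cc1ccnc2c1nc(C)n2Cc1ccc(-c2ccccc2C(=O)O)cc1` gives 50.1 nM in a functional assay (aorta) with Oryctolagus cuniculus as the target; on this read-out lower numbers stand for tighter binding and higher numbers for weaker binding
Compound 2 `CCc1nc2c(C)ccnc2n1Cc1ccc(-c2ccccc2C(=O)O)cc1` gives 1.26 nM
Compound 3 `Cc1ccnc2c1nc(C1CCC1)n2Cc1ccc(-c2ccccc2C(=O)O)cc1` gives 5.01 nM

Compound 3 at 5.01 nM takes the middle place of the three, with compound 2 lower and compound 1 higher. The change to compound 4 `CCSc1nc2c(C)ccnc2n1Cc1ccc(-c2ccccc2C(=O)O)cc1` is ethylsulfanyl in place of cyclobutyl on an aromatic carbon and the place is an aromatic carbon between two ring nitrogen atoms, the same carbon that varies among the measured compounds.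

Among the compounds with values here, three measured steps bear on this carbon. Ethyl in place of methyl gives a 40-fold lower number from compound 1 to compound 2 (1.60 log units; beyond the scatter) and is large. Cyclobutyl in place of methyl gives a 10-fold lower number from compound 1 to compound 3 (1.00 log units; beyond the scatter) and is modest. Cyclobutyl in place of ethyl gives a 4.0-fold higher number from compound 2 to compound 3 (0.60 log units; beyond the scatter) and is also modest. Ethylsulfanyl is an open chain like ethyl, so a small step downward in this assay is expected, towards compound 2 at 1.26 nM and near the edge of the scatter. No group linked through sulfur has been measured in this set, so the range stays wide. The expected move is a 2.0-fold lower number from compound 3 to compound 4 (0.30 log units; within the scatter) on this reasoning. Compound 4 is estimated at 2.5 nM with an expected range of 0.6 nM to 10 nM for the measurement to come.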

Compound 4, dissociation constant: 5.01 nM
Beside the measured number, compound 4's estimate is 2.0-fold (0.30 log units) below it, and the stated range covers the measured number.
By their numbers in this assay, from the lowest: compound 2; then compounds 3 and 4 (each within the scatter of the next); then compound 1.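

In this assay, the step at this aromatic carbon between two ring nitrogen atoms reads no change at the digits printed from compound 3 to compound 4 (within the scatter), so the numbers do not separate ethylsulfanyl, an open chain with no ring, from cyclobutyl, a four-membered non-aromatic ring. Set against the smaller groups, ethylsulfanyl gives a 4.0-fold higher number from compound 2 to compound 4 (0.60 log units; beyond the scatter) and a 10-fold lower number from compound 1 to compound 4 (1.00 log units; beyond the scatter), which shows that an open chain does not by itself match ethyl here and places ethylsulfanyl with cyclobutyl, short of ethyl but clear of methyl, while compound 2 keeps the lowest number of the four with all its steps beyond the scatter. No measured information on the compounds gives a reason for any of these steps.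

Going by these compounds, whether the sulfur atom or the chain length sets the number for ethylsulfanyl stays open, and propyl, ethoxy and ethylamino at the same carbon would be the direct comparisons for that. Whether the level shared by compound 3 and compound 4 is a general floor for groups larger than ethyl also stays open, since a longer chain such as butyl or a larger ring such as cyclohexyl lies outside the compounds shown.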